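The source may report more compounds than this note shows. Statements on the series, on what has been measured and on what is new or still open speak of the compounds shown alone.

Working notes on the series, read in a functional assay on A-375 cells (Homo sapiens) for activation, with a stated time of 3 days; a higher number here means that more compound is needed for the effect, a lower number that less compound is needed. Compound 1 `O=C(Nc1ccc(-c2ccccc2)cc1)C1CCCN(Cc2ccc(F)c(F)c2)C1` gives 5000 nM, compound 2 `O=C(Nc1ccc(-c2ccn[nH]2)cc1)C1CCCN(Cc2ccc(F)c(F)c2)C1` gives 580 nM, and compound 3 `O=C(Nc1ccc(-c2ccsc2)cc1)C1CCCN(Cc2ccc(F)c(F)c2)C1` gives 1930 nM, the middle number of the three. The next change leads to compound 4 `O=C(Nc1ccc(-c2ccc[nH]2)cc1)C1CCCN(Cc2ccc(F)c(F)c2)C1`, with 1H-pyrrol-2-yl in place of thiophen-3-yl on an aromatic carbon, para to a large group: 1H-pyrrol-2-yl in place of thiophen-3-yl on an aromatic carbon.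

Among the compounds with values here, no measured compound carries 1H-pyrrol-2-yl, so the expectation rests on neighbouring replacements at this place. The closest guide is a 3.3-fold higher number from compound 2 to compound 3 (0.52 log units; beyond the scatter), which leaves 1H-pyrazol-5-yl on the lower side. The phenyl replacements give an 8.6-fold lower number from compound 1 to compound 2 (0.94 log units; beyond the scatter) and a 2.6-fold lower number from compound 1 to compound 3 (0.41 log units; beyond the scatter), and again the 1H-pyrazol-5-yl of compound 2 has the lower number. A modest step to a lower number is therefore expected, probably somewhat smaller than the step separating compound 2 from compound 3. The expected change is a 2.3-fold lower number from compound 3 to compound 4 (0.36 log units; beyond the scatter). The estimate for compound 4 is 850 nM, with an expected range of 320 nM to 2300 nM.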

Compound 4, half-maximal effective concentration: 720 nM
Compound 4: middle estimate off by 1.2-fold (0.07 log units), on the high side; low and high end bracket the measured number.
By their numbers in this assay, from the lowest: compounds 2 and 4 (each within the scatter of the next); then compound 3; then compound 1.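

Thiophen-3-yl and 1H-pyrrol-2-yl each have one five-membered aromatic ring with 1 hetero atom, yet exchanging them on this aromatic carbon, para to a large group, gives a 2.7-fold lower number from compound 3 to compound 4 (0.43 log units; beyond the scatter), so ring size and hetero atom count do not settle the number in this assay. The second ring with a ring nitrogen does not separate from the first, with a 1.2-fold higher number from compound 2 to compound 4 (0.09 log units; within the scatter), while the step from the six-membered ring stays large, with a 6.9-fold lower number from compound 1 to compound 4 (0.84 log units; beyond the scatter). Nothing at hand explains these differences.

In the exchange from compound 3 to compound 4, sulfur gives way to nitrogen as a hydrogen-bond donor enters, so the two changes cannot be separated. From the compounds shown here alone, how an amine or a carboxylic acid on this aromatic carbon would read remains open.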